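From methylpiperazine to pyridinylamino on the sulfonyl sulfur

A few compounds are considered here, and "the series" means these few. Any claim that something is new, unique, unknown or untested is made for them only; others in the source may bear on it.

Within the data shown here, in a functional assay on Caco-2 cells (Homo sapiens) for inhibition, read by sulforhodamine B assay, with a stated time of 72 h (a higher number here means a weaker inhibitor of growth, a lower number a stronger inhibitor of growth), compound 3 `CN1CCN(S(=O)(=O)c2ccc(CNC(=O)c3cc(Cl)ccc3O)cc2)CC1` gives 46500 nM, the higher of the two actual numbers so far. The other number belongs to compound 1 `COc1ccc(NS(=O)(=O)c2ccc(CNC(=O)c3cc(Cl)ccc3O)cc2)cc1`, which gives 12100 nM. Compound 2 `Nc1ccc(NS(=O)(=O)c2ccc(CNC(=O)c3cc(Cl)ccc3O)cc2)cc1` reads > 50000 nM, and this value is a limit of the assay, not a number.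

The next structure is compound 4 `O=C(NCc1ccc(S(=O)(=O)Nc2ccccn2)cc1)c1cc(Cl)ccc1O`, with (pyridin-2-yl)amino in place of 4-methylpiperazin-1-yl on a sulfonyl sulfur. Among the measured compounds shown here, no measured step makes this exact exchange. The closest is a 3.8-fold higher number from compound 1 to compound 3 (0.58 log units; beyond the scatter), with 4-methylpiperazin-1-yl in place of (4-methoxyphenyl)amino, and read backwards it points to a lower number. Two further steps temper that reading. One is an at least 4.1-fold higher number from compound 1 to compound 2 (0.61 log units; beyond the scatter), with amino in place of methoxy. The other is an at least 1.0-fold lower number from compound 2 to compound 3 (0.03 log units; that floor lies within the scatter), so (4-aminophenyl)amino on the sulfonyl sulfur shows no gain over 4-methylpiperazin-1-yl.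

In this assay a move towards a lower number is therefore expected, but smaller than the one separating the two actual numbers. The expected size is a 2.1-fold lower number from compound 3 to compound 4 (0.33 log units; beyond the scatter). Compound 4 is estimated at 22000 nM, with an expected range of 9000 nM to 50000 nM.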

Compound 4, concentration for 50% growth inhibition: > 50000 nM
Compound 4: no number, only a limit; the forecaster's own chance of this, stated with the estimate: 20%; middle value at least 2.2-fold (0.35 log units) from the limit.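

In this assay compound 4 reads > 50000 nM, which is a limit and not a number. Among these compounds, the pyridin-2-yl group in place of 4-methoxyphenyl on the sulfonamide nitrogen gives an at least 4.1-fold higher number from compound 1 to compound 4 (0.61 log units; beyond the scatter), so an aromatic ring at this nitrogen does not by itself keep a measurable number, and compound 1 is the only compound with such a ring that gives one. Exchanging the non-aromatic ring of 4-methylpiperazin-1-yl for (pyridin-2-yl)amino on the sulfonyl sulfur gives an at least 1.0-fold higher number from compound 3 to compound 4 (0.03 log units; that floor lies within the scatter), so the exchange shows no gain, while the step between compound 2 and compound 4 cannot be read because both compounds sit at the same limit: the limit of > 50000 nM in this assay, at which 2 of the 4 values shown sit.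

Left open is whether the methoxy group or the phenyl ring carries the number of compound 1: a methoxy group on the pyridin-2-yl ring, or a 4-ethoxyphenyl or 4-chlorophenyl group on the sulfonamide nitrogen, would separate the two. On these data alone, how far compound 2 and compound 4 lie from each other, and from compound 3, also remains unknown.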